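The source may report more compounds than this note shows. Statements on the series, on what has been measured and on what is new or still open speak of the compounds shown alone.

Compound 1 `c1ccc(-c2ccc3c(NCCCNCc4ccco4)ccnc3c2)cc1` is one of three compounds that have been tested in a physicochemical assay for solubility, with a stated time of 18 h, at pH 7.4; a higher number here means a more soluble compound, a lower number a less soluble compound. In this assay compound 1 gives 32000 nM, level with compound 3 `COc1cccc(CNCCCNc2ccnc3cc(-c4ccccc4)ccc23)c1O`, which gives 32000 nM; together these two stand as the highest of the three numbers. Compound 2 `COc1ccc(F)cc1CNCCCNc1ccnc2cc(CCc3ccccc3)ccc12` is the furthest from compound 1, with a lower number beyond the scatter. In this assay compound 2 gives 4200 nM. Going by the values given here, only one measured step joins two compounds that differ in a single place: the step of no change at the digits printed from compound 1 to compound 3 (within the scatter), in which a 2-hydroxy-3-methoxyphenyl replaced a furan-2-yl on a saturated chain carbon bound to an amine nitrogen, left the number unchanged.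

Compound 4 `FC(F)(F)c1ccc(-c2ccc3c(NCCCNCc4ccco4)ccnc3c2)cc1` has not yet been measured. It differs from compound 1 in one place: trifluoromethyl in place of hydrogen on an aromatic carbon. Among the compounds with values here, the change sits on the six-membered aromatic ring, para to a large group, a part of the molecule that no measured step touches, and compound 2 differs from compound 1 in more than one place, so its value alone cannot be read as a step. The expectation therefore rests on little, and a moderate fall is estimated, a 2.7-fold lower number from compound 1 to compound 4 (0.43 log units; beyond the scatter), with wide uncertainty. Compound 4 is expected to give about 12000 nM, within a range from 4000 nM to 32000 nM.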

Compound 4, solubility: 32000 nM
Estimate against measurement, compound 4: 2.7-fold (0.43 log units) below; the range from low to high includes it.
By their numbers in this assay, from the lowest: compound 2; then compounds 1, 3 and 4 (each within the scatter of the next).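

In this assay, the change from phenyl to 4-(trifluoromethyl)phenyl gives no change at the digits printed from compound 1 to compound 4 (within the scatter), and this adds 4 heavy atoms on a six-membered aromatic ring of carbon only. Going by these compounds alone, the one earlier step, no change at the digits printed from compound 1 to compound 3 (within the scatter), changed only the group on the saturated chain carbon, so this is the first reading from the aromatic carbon para to a large group, and here a hydrogen can give way to trifluoromethyl with no difference beyond the scatter. Nothing measured in this set accounts for that result, which therefore stands as an observation without an explanation.

As far as these compounds go, it remains open whether this position would give a similar number with a different group in place of trifluoromethyl, such as a carboxylic acid, an amine or a nitrile. Within the data shown here, it is also open whether trifluoromethyl at this place would give a similar result alongside the 2-hydroxy-3-methoxyphenyl group of compound 3, since the single step here was read only with the furan-2-yl group of compound 1 in place.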